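Notes on three measured compounds and a carbamate variant

This account rests on a few compounds, and the source may have more. Where it says the series, first, only, none or still open, it means among the compounds named here.

Measured in a functional assay on MOLT-4F cells (Homo sapiens) for inhibition; a lower number here means a stronger inhibitor, a higher number a weaker inhibitor:
- compound 1 `C/C(=C\COC(=O)NC(C)(C)C)C1=CC(=O)C(C)(C)O1` gives 6.1 ug/mL
- compound 2 `C/C(=C\C=C/C1CCCCC1)C1=CC(=O)C(C)(C)O1` gives 7.1 ug/mL
- compound 3 `COc1ccc(/C=C/C=C(\C)C2=CC(=O)C(C)(C)O2)cc1` gives 10 ug/mL

Compound 1 gives the lowest of the three numbers, but its gap to compound 2 is within the scatter, and so is its gap to compound 3. No order among the three can be read from these values. The three share the core of compound 1 and differ in the side chain attached to it; no two of them differ in a single place, so the effect of any one change in this assay is not known from what has been measured.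

Compound 4 `C=CCNC(=O)OC/C=C(\C)C1=CC(=O)C(C)(C)O1` differs from compound 1 by allyl in place of tert-butyl on an amide-type nitrogen. The change sits on an amide-type nitrogen whose other neighbour is a carbonyl carbon. Among the measured compounds shown here, no measured step speaks to this change, so the expectation rests on the observation that three quite different side chains on the shared core gave numbers within the scatter of one another. On that basis the step of a 1.1-fold higher number from compound 1 to compound 4 (0.06 log units; within the scatter) is expected to be small, in no settled direction, and not beyond the scatter. Compound 4 is therefore estimated to give 7 ug/mL, with a range of 3.5 ug/mL to 14 ug/mL.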

Compound 4, half-maximal inhibitory concentration: 7.7 ug/mL
Compound 4: the middle estimate sits 1.1-fold (0.04 log units) below what was measured; the measured number falls inside the stated range.
By their numbers in this assay, from the lowest: compounds 1, 2, 4 and 3 (each within the scatter of the next).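

The pair compound 1 and compound 4 gives the series its first reading at a single place: in this assay, allyl in place of tert-butyl on an amide-type nitrogen gives a 1.3-fold higher number from compound 1 to compound 4 (0.10 log units; within the scatter). The earlier compounds shown here could show only that different side chains gave values within the scatter of one another, whereas this step shows that the group on this nitrogen can change from tert-butyl to allyl, bringing in a double bond outside aromatic rings, without a step beyond the scatter. No measurement on these compounds accounts for the two groups reading alike.

Among the compounds shown here, whether an amine, a carboxylic acid, a phenyl ring or a longer chain on the amide-type nitrogen would also stay within the scatter remains open, as the single step covers only tert-butyl and allyl. Also open, from the compounds shown here alone, is whether replacing the amide hydrogen, or the carbamate link itself, would move the number in this assay, and compound 2 and compound 3 differ from compound 4 in more than one place, so no steps can be read from them.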